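From ethoxycarbonyl to carboxy: a step from compound 1

The compounds below may be only part of what the source reports. "The series", "measured", "known", "first", "only" and "open" are said of these compounds alone.

Among the measured compounds shown here, compound 1 `CCOC(=O)c1nn(-c2ccc(Cl)cc2)c(-c2ccc(OC)cc2OC)c1C` is one of only two compounds measured so far. In a functional assay on the whole organism (strain albino) for inhibition, with Rattus norvegicus as the target, read by paw edema, with stated times of 30 min and 1 h, at a dose of 25 mg/kg by the intraperitoneal route (on this read-out higher numbers stand for more inhibition at the one dose given (going by the name of the read-out) and lower numbers for less inhibition), compound 1 gives 0%. For the measured compounds named here, its single measured neighbour is compound 2 `CCOC(=O)c1nn(-c2ccc(Cl)cc2)c(-c2ccc(OC)cc2OC)c1-c1ccccc1`, which in this assay gives 6.89%; the two numbers sit within the scatter of each other, so neither number can be called higher or lower than the other. Going by the values given here, the one step measured here, a number 6.9 percentage points higher from compound 1 to compound 2 (within the scatter), replaces methyl with phenyl on an aromatic carbon and thus concerns a different part of the molecule from the change now followed.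

Compound 3 `COc1ccc(-c2c(C)c(C(=O)O)nn2-c2ccc(Cl)cc2)c(OC)c1` differs from compound 1 in one place: hydrogen in place of ethyl on an oxygen next to a carbonyl group. Among the compounds with values here, no measured step touches this site. Within the data shown here, the only step available, from compound 1 to compound 2, lies within the scatter and sits elsewhere, so it gives no direction to borrow. For compound 3 a step within the scatter is therefore expected: a number 5 percentage points higher from compound 1 to compound 3 (within the scatter). Compound 3 is estimated to give 5% in this assay, with a range from 0% to 15%.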

Compound 3, a percentage reported as inhibition, in the whole organism at one dose (the size of the read-out at that dose, not a potency): 24.7%
Compound 3: middle estimate off by 19.7 percentage points, on the low side; measured number outside the range, above it.
By their numbers in this assay, from the lowest: compounds 1 and 2 (each within the scatter of the next); then compound 3.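

Replacing ethoxycarbonyl with carboxy, that is, hydrogen in place of ethyl on an oxygen next to a carbonyl group, gives a modest but readable change in this assay: a number 24.7 percentage points higher from compound 1 to compound 3 (beyond the scatter). Among the compounds shown here, this is the first step that rises beyond the usual scatter, so the group on this oxygen can change the inhibition seen at the one dose given, whereas the earlier change from methyl to phenyl on an aromatic carbon could not be told apart from scatter. Nothing measured here explains how this change raises the number, so the step stands as an observation without a known cause.

With only ethyl and hydrogen shown on this oxygen, the compounds leave open whether the higher number calls for the carboxylic acid itself or would also appear with a smaller methyl group, a longer chain such as butyl, or an amide in place of the acid. They also leave open whether carboxy would have a similar effect with phenyl instead of methyl on the aromatic carbon, and how the response would change at other doses.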